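Methylsulfonyl for methyl on the aromatic nitrogen

The compounds below may be only part of what the source reports. "The series", "measured", "known", "first", "only" and "open" are said of these compounds alone.

Of the compounds shown here, two on the shared core have numbers so far. Compound 1 `CNC(=O)N1CCCc2ccc(NC(=O)c3cccc(-c4cnn(C)c4)c3)cc21` stands highest of the two: in a functional assay on MV4-11 cells (Homo sapiens) for antiproliferative activity, with a stated time of 6 days, tested at 6.25 uM (on this read-out higher numbers stand for a stronger effect at the one concentration tested and lower numbers for a weaker effect), compound 1 gives 93.5%. Compound 2 `CNC(=O)N1CCCc2ccc(NC(=O)c3ccc(-c4ccn(S(C)(=O)=O)n4)cc3)cc21` is not a single-step partner of compound 1, since it differs from it in several positions. In this assay compound 2 gives 57.2%, a gap beyond the scatter; the two values show only that the second arrangement sits well below compound 1, and no single step can be read from them. Compound 3 `CNC(=O)N1CCCc2ccc(NC(=O)c3cccc(-c4cnn(S(C)(=O)=O)c4)c3)cc21` is the direct partner of compound 1: methylsulfonyl in place of methyl on an aromatic nitrogen. With no measured step of this kind in hand, the step from compound 1 to compound 3 is expected to be a loss beyond the scatter, a number 28.5 percentage points lower from compound 1 to compound 3 (beyond the scatter), with wide uncertainty. Compound 3 is estimated at 65% in this assay, with a range from 35% to 90%.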

Compound 3, a percentage reported as inhibition, at one concentration (the size of the read-out at that concentration, not a potency): 18%
For compound 3 the middle estimate is 47 percentage points above the measured one; the whole stated range lies above it.
By their numbers in this assay, from the lowest: compound 3; then compound 2; then compound 1.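

Among the compounds shown here, this is the first single-place step: in this assay, methylsulfonyl in place of methyl on the aromatic nitrogen gives a number 75.5 percentage points lower from compound 1 to compound 3 (beyond the scatter). The substituent on this nitrogen is therefore not a neutral position, since this one exchange, with the rest of the structure unchanged, removes most of the effect seen at the single concentration tested. Nothing at hand bears on why the step is so large.

The compounds shown leave open whether the loss goes with the sulfonyl group specifically or with any substituent larger than methyl on this nitrogen. An ethyl or acetyl group there, or a plain hydrogen on the nitrogen, would separate these readings, and a single step cannot say where such groups would fall.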